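This account rests on a few compounds, and the source may have more. Where it says the series, first, only, none or still open, it means among the compounds named here.

Measured in a functional assay on Lewis lung carcinoma cells (Mus musculus) for antiproliferative activity, read by MTT assay, with a stated time of 24 h; on this read-out lower numbers stand for stronger inhibition and higher numbers for weaker inhibition:
- Compound 1 `C=CCc1cc(-c2cccc(C(F)(F)F)c2)ccc1O`: 65900 nM
- Compound 2 `C=CCc1cc(-c2ccccc2)ccc1O`: > 100000 nM, a limit of the assay and not a number
- Compound 3 `C=CCc1cc(-c2ccccc2C(F)(F)F)ccc1O`: 60300 nM

Compound 2 has no exact number, only (the limit of > 100000 nM in this assay, at which 1 of the 3 values shown sits). Compound 4 `C=CCc1cc(-c2ccc(C(F)(F)F)cc2)ccc1O` differs from compound 2 by a single change: trifluoromethyl in place of hydrogen on an aromatic carbon. This trifluoromethyl group sits para to a large group.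

Two measured steps involve the same exchange of hydrogen and trifluoromethyl on an aromatic carbon: an at least 1.5-fold higher number from compound 1 to compound 2 (0.18 log units; that floor lies within the scatter) and an at least 1.6-fold lower number from compound 2 to compound 3 (0.21 log units; that floor lies within the scatter). On these data alone, both are only floors, and both floors lie within the scatter, so their true sizes remain unknown. Even so, each of the two compounds carrying trifluoromethyl gave a real number in this assay, with compound 1 at 65900 nM and compound 3 at 60300 nM. Compound 4 is therefore expected to land near these two values, although a result at the limit remains possible. The expected change is an at least 1.6-fold lower number from compound 2 to compound 4 (0.22 log units; that floor lies within the scatter), towards a lower number. For compound 4 the estimated value is 60000 nM, with an expected range of 35000 nM to 100000 nM.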

Compound 4, half-maximal inhibitory concentration: 74800 nM
Estimate against measurement, compound 4: 1.2-fold (0.10 log units) below, within the range that was stated.
By their numbers in this assay, from the lowest: compounds 3, 1 and 4 (each within the scatter of the next). At a limit, above all of these: compound 2.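

In this assay, trifluoromethyl para to a large group also gives a real number, so compound 4 joins compound 1 and compound 3: all three carry this group, and their values lie within the scatter of one another. On these data alone, the exchange on compound 2 gives an at least 1.3-fold lower number from compound 2 to compound 4 (0.12 log units; that floor lies within the scatter), so this step, like the two earlier ones, has a true size that remains unknown. Compound 2 has only a limit of the assay and not a number: the limit of > 100000 nM in this assay, at which 1 of the 4 values shown sits.

As far as these compounds go, it remains open whether another group at this place, such as a methyl, a nitrile, an amine or a carboxylic acid, would also give a number in this assay. Also open, from the compounds shown here alone, is whether any such group would lower the number by a step clearly beyond the scatter.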